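Swapping the pendant aryl group on a fused imidazopyrazine core

The source may report more compounds than this note shows. Statements on the series, on what has been measured and on what is new or still open speak of the compounds shown alone.

Measured in a functional assay on NCI-H460 cells (Homo sapiens) for inhibition, read by sulforhodamine B assay, with a stated time of 48 h, tested at 10 uM; a higher number here means more inhibition at the concentration tested (going by the name of the read-out), a lower number less inhibition:
Compound 1, `COc1ccc(-c2cn3ccnc3c(-c3ccc4ncn(C5CCCCC5)c4c3)n2)cc1`: compound 1 gives 91.1%.
Compound 2, `Fc1ccc(-c2cn3ccnc3c(-c3ccc4ncn(C5CCCCC5)c4c3)n2)cc1`: compound 2 gives 6.12%.
Compound 3, `CC(=O)c1ccc(-c2cn3ccnc3c(-c3ccc4ncn(C5CCCCC5)c4c3)n2)cc1`: compound 3 gives 7.12%.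

Compound 3 stands second highest of the three numbers; its nearest neighbour is compound 2, within the scatter, while compound 1 lies far above it. The step to compound 4, `COc1ccccc1-c1cn2ccnc2c(-c2ccc3ncn(C4CCCCC4)c3c2)n1`, is 2-methoxyphenyl in place of 4-acetylphenyl on an aromatic carbon.

The step that bears on this change is a number 84 percentage points lower from compound 1 to compound 3 (beyond the scatter), which shows that acetyl for methoxy on the same shared core cost a large amount of inhibition. Compound 4 reverses that exchange, though with the methoxy group now in a 2-methoxyphenyl rather than the arrangement of compound 1, so the recovery is uncertain. The step of a number 1 percentage points higher from compound 2 to compound 3 (within the scatter) adds nothing on methoxy. A large rise is expected, a number 47.9 percentage points higher from compound 3 to compound 4 (beyond the scatter), but with a wide range. Compound 4 is therefore estimated at 55%, between 15% and 90%.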

Compound 4, a percentage reported as inhibition, at one concentration (the size of the read-out at that concentration, not a potency): 9.62%
Compound 4: middle estimate off by 45.4 percentage points, on the high side, and the stated range ends above it.
By their numbers in this assay, from the lowest: compounds 2, 3 and 4 (each within the scatter of the next); then compound 1.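

In this assay there is a number 81.5 percentage points lower from compound 1 to compound 4 (beyond the scatter) when 2-methoxyphenyl replaces 4-methoxyphenyl on this aromatic carbon, so carrying a methoxy group does not by itself keep the inhibition. There is also a number 2.5 percentage points higher from compound 3 to compound 4 (within the scatter) and a number 3.5 percentage points higher from compound 2 to compound 4 (within the scatter) so the 2-methoxyphenyl, 4-acetylphenyl and 4-fluorophenyl groups cannot be told apart here, and only the 4-methoxyphenyl group stands out. Nothing available explains this difference.

Still open, going by these compounds, is whether an ethoxy or a dimethylamino group, placed where compound 1 carries its methoxy, would keep that compound's inhibition.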